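Adding chloro to compound 3: expected growth inhibition

The source may hold more compounds than are shown below. What is called first, only, known or untested is meant among the compounds shown, and "the series" means these compounds.

Values in a functional assay on HeLa cells (Homo sapiens) for inhibition, read by MTT assay, with a stated time of 48 h; a lower number here means a stronger inhibitor of growth, a higher number a weaker inhibitor of growth:
Compound 1 `Cn1cc(C2CC(c3ccccc3)=NN2C(=O)c2cccnc2)c2ccccc21`: > 10000 nM, a limit of the assay
Compound 2 `COc1ccc2c(c1)c(C1CC(c3ccccc3)=NN1C(=O)c1cccnc1)cn2C`: 3590 nM
Compound 3 `COc1ccc2c(c1)c(C1CC(c3ccccc3)=NN1C(=O)c1ccc(OC)nc1)cn2C`: 1100 nM

Of the two actual numbers in this assay, the lower belongs to compound 3 at 1100 nM, and compound 2 stands at 3590 nM. The next structure is compound 4 `COc1ccc2c(c1)c(C1CC(c3ccc(Cl)cc3)=NN1C(=O)c1ccc(OC)nc1)cn2C`, with the change chloro in place of hydrogen on an aromatic carbon, which turns phenyl into 4-chlorophenyl. For the measured compounds named here, no measured step touches this ring or brings in chloro. The closest guides are two methoxy-for-hydrogen steps elsewhere in the molecule, an at least 2.7-fold lower number from compound 1 to compound 2 (0.44 log units; beyond the scatter) and a 3.3-fold lower number from compound 2 to compound 3 (0.51 log units; beyond the scatter). Both lowered the number, but they involve another group at other places, so they bear on this change only loosely. Given the size of a 3.3-fold lower number from compound 2 to compound 3 (0.51 log units; beyond the scatter), a modest move to a lower number is expected, though a result within the scatter remains possible. The estimated step is a 1.5-fold lower number from compound 3 to compound 4 (0.17 log units; within the scatter). Compound 4 is estimated at 750 nM, with an expected range of 250 nM to 2200 nM.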

Compound 4, concentration for 50% growth inhibition: 2260 nM
Compound 4: middle estimate off by 3.0-fold (0.48 log units), on the low side; measured number above the stated range.
By their numbers in this assay, from the lowest: compound 3; then compounds 4 and 2 (each within the scatter of the next). At a limit, above all of these: compound 1.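

In this assay, for the compounds shown here, chloro in place of hydrogen on the phenyl gives a 2.1-fold higher number from compound 3 to compound 4 (0.31 log units; beyond the scatter) and is the first measured change at this place. The earlier methoxy steps elsewhere in the molecule both lowered the number, most closely a 3.3-fold lower number from compound 2 to compound 3 (0.51 log units; beyond the scatter), so compound 4 goes against any reading that adding a group lowers it, and this carbon, para to a large group, does respond to substitution. Nothing shown here accounts for the direction of this step.

On these data alone, it remains open whether the upward move belongs to chloro itself or would follow any group on this carbon; methoxy, an amine or a carboxylic acid in the same place would separate these readings. Also open, as far as these compounds go, is whether the step keeps its size and direction on the core of compound 2.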